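The source may hold more compounds than are shown below. What is called first, only, known or untested is meant among the compounds shown, and "the series" means these compounds.

Working notes on the series, followed in a functional assay on MGC-803 cells (Homo sapiens) for inhibition, read by sulforhodamine B assay; a higher number here means a weaker inhibitor, a lower number a stronger inhibitor. Compound 1 (`O=C1C=C(N2CCC2)C(=O)c2c1nc1n2[C@H]2OC[C@@H](O)[C@H]2OC1`) gives > 16000 nM as its result, which is a limit and not a number. Compound 2 (`O=C1C=C(NC2CCCC2)C(=O)c2c1nc1n2[C@H]2OC[C@@H](O)[C@H]2OC1`) gives > 8000 nM as its result, which is also only a limit, so its position is not fixed by a number. Among the compounds with values here, compound 3 (`O=C1C(Nc2ccc(C(F)(F)F)cc2)=CC(=O)c2c1nc1n2[C@H]2OC[C@@H](O)[C@H]2OC1`), the only measured compound with an aromatic ring on the amine nitrogen, gives 1860 nM as the one true number so far.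

Compound 4 (`CCOc1ccccc1NC1=CC(=O)c2nc3n(c2C1=O)[C@H]1OC[C@@H](O)[C@H]1OC3`) follows from compound 2 with 2-ethoxyphenyl in place of cyclopentyl on an amine nitrogen. Within the data shown here, the only measured step is a step that the two limits leave unreadable from compound 1 to compound 2 and it offers no size to carry over. Among the measured compounds shown here, the sole guide is therefore compound 3 at 1860 nM, which differs from compound 4 in more than one place and so supports only a loose expectation.

The expected change is an at least 2.2-fold lower number from compound 2 to compound 4 (0.35 log units; beyond the scatter) and its expected direction is towards a stronger inhibitor, though a further limit remains possible. Compound 4 is estimated to give 3500 nM in this assay (expected range 1000 nM to 12000 nM).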

Compound 4, half-maximal inhibitory concentration: 2450 nM
Compound 4: the middle estimate sits 1.4-fold (0.15 log units) above what was measured; low and high end bracket the measured number.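

In this assay, within the data shown here, the change on the amine nitrogen gives the first step with a readable direction, as 2-ethoxyphenyl in place of cyclopentyl lowers the number and so points towards a stronger inhibitor (an at least 3.2-fold lower number from compound 2 to compound 4 (0.51 log units; beyond the scatter)). Among the compounds shown, the two with an aromatic ring on the amine nitrogen, compound 3 and compound 4, give true numbers, while compound 1 and compound 2, with azetidin-1-yl and cyclopentyl at this kind of place, stand only at limits, and no compound shown goes against this. Compound 2 stands at a limit of the assay and not at a number, so the step has a floor and no fixed size: the limit of > 8000 nM in this assay, at which 1 of the 4 values shown sits.

The change brings in an aromatic ring and an ether oxygen together, and the step cannot tell which of the two goes with the lower number. A plain phenyl or a benzyl on the amine nitrogen would separate these parts, and the compounds shown leave open how much of the step belongs to the ethoxy group.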